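Series notes: ring swap on the aromatic carbon

The source may report more compounds than this note shows. Statements on the series, on what has been measured and on what is new or still open speak of the compounds shown alone.

Compound 3 `CC(C(=O)NCc1ccc(C(F)(F)F)nc1C1=C[C@H](C)CCC1)c1ccc(NS(C)(=O)=O)c(F)c1` stands lowest of the three numbers in an assay on CHO cells for antagonist activity at transient receptor potential cation channel subfamily V member 1 (Homo sapiens), read by FLIPR and calcium flux (a higher number here means a weaker inhibitor, a lower number a stronger inhibitor), with 0.1 nM; compound 2 `CCC1CCC(c2nc(C(F)(F)F)ccc2CNC(=O)C(C)c2ccc(NS(C)(=O)=O)c(F)c2)CC1` gives 0.3 nM, and compound 1 `Cc1nc(C(F)(F)F)ccc1CNC(=O)C(C)c1ccc(NS(C)(=O)=O)c(F)c1` gives 387 nM. Going by the values given here, the two large steps, a 1300-fold lower number from compound 1 to compound 2 (3.11 log units; beyond the scatter) and a 3900-fold lower number from compound 1 to compound 3 (3.59 log units; beyond the scatter), show that a six-membered carbocycle in place of methyl on this aromatic carbon is what carries the potency; the modest step of a 3.0-fold lower number from compound 2 to compound 3 (0.48 log units; beyond the scatter) is the only comparison between two such rings.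

Compound 4 `CC(C(=O)NCc1ccc(C(F)(F)F)nc1C1=CCC(C)(C)CC1)c1ccc(NS(C)(=O)=O)c(F)c1` is the next member: 4,4-dimethylcyclohex-1-en-1-yl in place of 3-methylcyclohex-1-en-1-yl on an aromatic carbon. Both the leaving and the entering group are a cyclohexenyl ring, differing only in how the methyls sit on it, so the relevant precedent is a 3.0-fold lower number from compound 2 to compound 3 (0.48 log units; beyond the scatter) rather than the two large steps from compound 1. A change of that order or smaller is expected, in either direction, with no firm reason from the measured compounds to expect it beyond the scatter; compound 4 is expected to give 0.2 nM in this assay, between 0.05 nM and 0.8 nM, a step of a 2.0-fold higher number from compound 3 to compound 4 (0.30 log units; within the scatter).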

Compound 4, inhibition constant: 0.2 nM
Estimate against measurement, compound 4: no gap at the digits printed; the measured number falls inside the stated range.
By their numbers in this assay, from the lowest: compounds 3, 4 and 2 (each within the scatter of the next, the first and the last beyond it); then compound 1.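

In this assay, moving from one methyl on the cyclohexenyl ring to two gives a 2.0-fold higher number from compound 3 to compound 4 (0.30 log units; within the scatter), and replacing the saturated 4-ethylcyclohexyl ring with the 4,4-dimethylcyclohex-1-en-1-yl ring gives a 1.5-fold lower number from compound 2 to compound 4 (0.18 log units; within the scatter), so this position tolerates all three ring variants without a step beyond the scatter from compound 4. The entering ring has no defined stereocentre, so a defined stereocentre on the ring is not required for a number of this size. The third ring in place of methyl gives a 1900-fold lower number from compound 1 to compound 4 (3.29 log units; beyond the scatter), and all three ring compounds now show a large step from compound 1, with none going against it.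

On these data alone, whether an amine-bearing ring such as piperidin-1-yl, or an open chain such as isopropyl, holds numbers of this size remains open. No measurement shown explains why these rings read alike.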